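The source may hold more compounds than are shown below. What is called first, only, known or untested is meant among the compounds shown, and "the series" means these compounds.

Working notes on the choline kinase alpha series. Compound 1 `CN1CCCN(Cc2ccc(-c3ccc(CN4CCCN(C)CC4)c(Cl)c3)cc2)CC1`, compound 2 `CN1CCCN(Cc2ccc(-c3ccccc3)cc2)CC1` and compound 3 `O=C(N1CCCCCC1)N1CCNCC1` have been run in an assay on isolated protein for binding affinity to choline kinase alpha (Homo sapiens), read by surface plasmon resonance; a higher number here means weaker binding, a lower number tighter binding. Compound 1 gives 88 nM, compound 2 gives 3700 nM and compound 3 gives 340000 nM. Compound 2 thus stands second highest of the three numbers in this assay, between compound 1 and compound 3, and both of those gaps lie beyond the scatter.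

Compound 4 `COC(=O)c1ccc(-c2ccc(CN3CCCN(C)CC3)cc2)cc1` has not been measured in this assay. It differs from compound 2 in one place: methoxycarbonyl in place of hydrogen on an aromatic carbon.

Going by the values given here, no comparable step among the measured compounds is available, so the expected size of the step in this assay is uncertain. A small move toward tighter binding, possibly within the scatter, is expected, giving a 1.9-fold lower number from compound 2 to compound 4 (0.27 log units; within the scatter). Compound 4 is accordingly estimated at 2000 nM, with a range from 600 nM to 7000 nM.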

Compound 4, dissociation constant: 2400 nM
Estimate against measurement, compound 4: 1.2-fold (0.08 log units) below, and the stated range covers the measured number.
By their numbers in this assay, from the lowest: compound 1; then compounds 4 and 2 (each within the scatter of the next); then compound 3.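

Methoxycarbonyl in place of hydrogen on an aromatic carbon, para to a large group, gives in this assay a 1.5-fold lower number from compound 2 to compound 4 (0.19 log units; within the scatter) and so leaves the number within the scatter. Going by these compounds alone, this is the first single-place step, and it shows that this position carries methoxycarbonyl with no readable change in binding. No available evidence bears on this result.

On these data alone, whether a carboxylic acid, a primary amide or an amine on this carbon would give a step of similar size stays open. So does whether methoxycarbonyl would behave the same way on the core of compound 1.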